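The compounds below may be only part of what the source reports. "The series", "measured", "known", "first", "only" and "open" are said of these compounds alone.

Compound 3 `COc1cc2c(Oc3c(F)cc(NC(=O)NN4C(=O)CSC4c4c(F)cccc4F)cc3F)ccnc2cc1OCCCN1CCC(C)CC1` gives the lowest number of the three measured compounds in a functional assay on HT-29 cells (Homo sapiens) for antiproliferative activity, read by MTT assay, with a stated time of 72 h (a higher number here means a weaker inhibitor, a lower number a stronger inhibitor), at 220 nM. Compound 1 `COc1cc2c(Oc3c(F)cc(NC(=O)NN4C(=O)CSC4c4c(F)cccc4F)cc3F)ccnc2cc1OCCCN1CCCC1` gives 230 nM in this assay, and the change a 1.0-fold lower number from compound 1 to compound 3 (0.02 log units; within the scatter) stays within the scatter. Compound 2 `COc1cc2c(Oc3c(F)cc(NC(=O)NN4C(=O)CSC4c4c(F)cccc4F)cc3F)ccnc2cc1OCCCN1CCc2sccc2C1` gives 1410 nM in this assay, and the change a 6.4-fold lower number from compound 2 to compound 3 (0.81 log units; beyond the scatter) lies beyond it. Compound 4 `COc1cc2c(Oc3c(F)cc(NC(=O)NN4C(=O)CSC4c4c(F)cccc4F)cc3F)ccnc2cc1OCCCN1CCN(C)CC1` carries 4-methylpiperazin-1-yl in place of 4-methylpiperidin-1-yl on a saturated chain carbon, three bonds along the chain from an oxygen on an aromatic ring. Going by the values given here, of the measured steps, the one from compound 1 to compound 3 is the closer parallel, since both steps exchange one small saturated amine ring for another of similar size, and it produced no change beyond the scatter; the step from compound 2 to compound 3 removed a much larger group and is less informative here. Among the compounds with values here, no measured pair separates a ring carbon from a ring nitrogen, so the expectation rests on the size of the group alone. The step of no change at the digits printed from compound 3 to compound 4 (within the scatter) is therefore expected to stay within the scatter. Compound 4 is expected to give about 220 nM in this assay, with a range from 80 nM to 600 nM.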

Compound 4, half-maximal inhibitory concentration: 150 nM
The estimate for compound 4 lay 1.5-fold (0.17 log units) above the measured number; the range from low to high includes it.
By their numbers in this assay, from the lowest: compounds 4, 3 and 1 (each within the scatter of the next); then compound 2.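

In this assay the exchange of 4-methylpiperidin-1-yl for 4-methylpiperazin-1-yl, which puts a second nitrogen into the ring at this place on the chain, gives a 1.5-fold lower number from compound 3 to compound 4 (0.17 log units; within the scatter) and so does not separate the two groups. The same group also cannot be told apart from pyrrolidin-1-yl, with a 1.5-fold lower number from compound 1 to compound 4 (0.19 log units; within the scatter), whereas the larger group of compound 2 stands clearly apart, with a 9.4-fold lower number from compound 2 to compound 4 (0.97 log units; beyond the scatter) on replacement by 4-methylpiperazin-1-yl. Nothing available explains why these groups give such close numbers.

The compounds shown leave open whether a morpholin-4-yl ring or an open-chain dimethylamino group at the end of the propyl chain would stay with compounds 1, 3 and 4. They also leave open whether 4-methylpiperazin-1-yl would behave the same way on a longer chain.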